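This account rests on a few compounds, and the source may have more. Where it says the series, first, only, none or still open, it means among the compounds named here.

Measured compounds:
compound 1 `Cc1c(O)c(=O)ccn1CC(=O)N/N=C1\C(=O)N(CC(=O)Nc2ccc(Cl)cc2)c2ccccc21` — 28300 nM
compound 2 `Cc1cccc(NC(=O)CN2C(=O)/C(=N\NC(=O)Cn3ccc(=O)c(O)c3C)c3ccccc32)c1C` — 39200 nM

In a functional assay on A549 cells (Homo sapiens) for cytotoxicity, read by MTT assay, with a stated time of 48 h (on this read-out higher numbers stand for an effect only at larger amounts of compound and lower numbers for an effect already at smaller amounts), compound 2 gives 39200 nM, and compound 1 gives 28300 nM. On the two numbers shown compound 2 stands alongside compound 1: the step of a 1.4-fold higher number from compound 1 to compound 2 (0.14 log units; within the scatter) lies within the scatter, so the two compounds cannot be told apart on this read-out. That step consisted of an exchange of the aryl group on the amide-type nitrogen, 2,3-dimethylphenyl in place of 4-chlorophenyl.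

Compound 3 `Cc1c(O)c(=O)ccn1CC(=O)N/N=C1\C(=O)N(CC(=O)Nc2cc(Cl)cc(Cl)c2)c2ccccc21` differs from compound 2 in the same place: 3,5-dichlorophenyl in place of 2,3-dimethylphenyl on an amide-type nitrogen. Among the measured compounds shown here, the only measured step that bears on this change is the one from compound 1 to compound 2, an aryl exchange on the same amide-type nitrogen, and it stayed within the scatter. On that basis no step beyond the scatter is expected in this assay for compound 3, in either direction, and the expected step of a 1.1-fold lower number from compound 2 to compound 3 (0.05 log units; within the scatter) reflects this. Compound 3 is therefore estimated at 35000 nM in this assay, with a range from 15000 nM to 80000 nM.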

Compound 3, half-maximal effective concentration: 22100 nM
Compound 3: the middle estimate sits 1.6-fold (0.20 log units) above what was measured, within the range that was stated.
By their numbers in this assay, from the lowest: compounds 3, 1 and 2 (each within the scatter of the next).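

In this assay, the exchange on the amide-type nitrogen gives a 1.8-fold lower number from compound 2 to compound 3 (0.25 log units; within the scatter), and a second exchange at the same place, from a single chlorine on the phenyl ring to two, gives a 1.3-fold lower number from compound 1 to compound 3 (0.11 log units; within the scatter). Among the compounds shown here, with the earlier step, this means that 4-chlorophenyl, 2,3-dimethylphenyl and 3,5-dichlorophenyl can all be compared directly at this position, and no step among the three leaves the scatter, so the three compounds cannot be told apart on this read-out. Nothing is available here that would account for this result.

On these data alone, all three groups are substituted phenyl rings, so it remains open whether an aminophenyl or carboxyphenyl group, a pyridyl ring or a simple alkyl chain on the amide-type nitrogen would give a step beyond the scatter in this assay. The three compounds also share the core of compound 1 unchanged, which leaves open what an exchange elsewhere in the molecule, such as at the methyl group or the hydroxyl group of the core, would do.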